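Cyclopentyl ether on the shared core of compound 1

This account rests on a few compounds, and the source may have more. Where it says the series, first, only, none or still open, it means among the compounds named here.

The series shares one core, seen in compound 1 `COc1ccc(-c2noc(-c3ccc(F)cc3)n2)cc1O`, and is read in a functional assay on PC-3 cells (Homo sapiens) for antiproliferative activity, read by MTT assay, with a stated time of 24 h; on this read-out higher numbers stand for weaker inhibition and lower numbers for stronger inhibition. Compound 1 stands at the limit of the assay: in this assay compound 1 gives > 1000000 nM, which is a limit and not a number. Compound 2 `COc1cc(-c2noc(-c3ccncc3)n2)ccc1OCc1ccccc1` sits at the same limit, giving > 1000000 nM in this assay. Compound 3 `COc1ccc(-c2noc(-c3ccc(Cl)cc3)n2)cc1OC1CCCC1` likewise gives > 1000000 nM in this assay, again a limit. Among the measured compounds shown here, the evidence on the measured values is therefore confined to the limit of > 1000000 nM in this assay, at which 3 of the 3 values shown sit; no step between two numbers exists here.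

Compound 4 `COc1ccc(-c2noc(-c3ccc(F)cc3)n2)cc1OC1CCCC1` is not yet measured. It differs from compound 1 by cyclopentyl in place of hydrogen on an oxygen on an aromatic ring. Compound 3 already carries the same cyclopentyl group on the same oxygen and sits at the limit, so no ground appears for a step beyond the scatter in either direction.

The step that the limit leaves unreadable from compound 1 to compound 4 is therefore expected to be none beyond the scatter. Compound 4 is expected to give 1500000 nM in this assay, between 500000 nM and 5000000 nM, most likely reported only as the same limit.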

Compound 4, half-maximal inhibitory concentration: > 1000000 nM
Compound 4: a limit, no number; the forecaster's own chance of this, stated with the estimate: 90%; the middle value is on the limit's open side.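

Compound 4 gives > 1000000 nM in this assay, a limit and not a number. The steps to compound 4 from compound 1 and from compound 3 therefore cannot be read: the limit of > 1000000 nM in this assay, at which 4 of the 4 values shown sit.

The compounds shown leave open whether cyclopentyl in place of hydrogen, or fluoro in place of chloro, changes the read-out at all in this assay.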